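This account rests on a few compounds, and the source may have more. Where it says the series, first, only, none or still open, it means among the compounds named here.

Measured so far:
compound 1 `CCCCOC(=O)/C=C(C)/C=C/CC(C)CCCC(C)(C)OC`, 6.62
compound 2 `CCOC(=O)/C=C(C)/C=C/CC(C)CCCC(C)(C)SC`, 6.36
compound 3 `C=C(C)CCCC(C)C/C=C/C(C)=C/C(=O)OC(C)C`, 6.6

In a physicochemical assay for lipophilicity (a lower number here means a more polar compound, a higher number a more lipophilic compound), compound 1 gives the highest of the three numbers, but compound 3 lies only a hair lower and compound 2 a little further down, both within the scatter, so no order among the three can be claimed. Compound 4 `CCC(=O)/C=C(C)/C=C/CC(C)CCCC(C)(C)OC` has not yet been measured. It differs from compound 1 in one place: ethyl in place of butoxy on a carbonyl carbon. Going by the values given here, no pair among the measured compounds shows this change, so the size of the step rests on the structural change alone. A downward step well beyond the scatter is expected, since two carbon atoms and an oxygen leave and only a two-carbon chain enters. The estimate for compound 4 in this assay is 5.2, with a range from 4.6 to 5.8, a step of a number 1.42 log units lower from compound 1 to compound 4 (beyond the scatter).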

Compound 4, partition coefficient: 5.07
Beside the measured number, compound 4's estimate is 0.13 log units above it, and the stated range covers the measured number.
By their numbers in this assay, from the lowest: compound 4; then compounds 2, 3 and 1 (each within the scatter of the next).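

In this assay, going by these compounds alone, ethyl in place of butoxy on a carbonyl carbon gives a number 1.55 log units lower from compound 1 to compound 4 (beyond the scatter) and so brings the first step that can be read, showing that this position responds strongly to the change. The same difference reads as butoxycarbonyl to propanoyl. No measured property in hand bears on the origin of this step.

The compounds shown leave open how the step divides between the chain and the oxygen. A pentyl chain or an amine on the same carbonyl carbon would bear on that.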